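From benzyloxycarbonyl to carbamoyl on the shared core

This account rests on a few compounds, and the source may have more. Where it says the series, first, only, none or still open, it means among the compounds named here.

Three compounds on the shared core have readings so far. In a physicochemical assay for solubility, read by nephelometry, in phosphate buffer, measured as kinetic solubility, at pH 6.5 (on this read-out lower numbers stand for lower solubility and higher numbers for higher solubility), compound 1 `CCOC(=O)C1=C(C)N/C(=C/c2cc(C)n(-c3ccc(N(C)C)cc3)c2C)C1=O` gives < 1.6 ug/mL, which is a limit of the assay and not a number. For the measured compounds named here, compound 2 `CCOC(=O)C1=C(C)N/C(=C/c2ccn(-c3ccc(C(F)(F)F)cc3)c2)C1=O` gives 1.6 ug/mL, the only true number in the set. Compound 3 `CC1=C(C(=O)OCc2ccccc2)C(=O)/C(=C\c2cc(C)n(-c3ccccc3C(F)(F)F)c2C)N1` gives < 1.6 ug/mL, again a limit of the assay. Compound 3 therefore has no number of its own and stands with compound 1 at the limit of < 1.6 ug/mL in this assay, at which 2 of the 3 values shown sit.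

Compound 4 `CC1=C(C(N)=O)C(=O)/C(=C\c2cc(C)n(-c3ccccc3C(F)(F)F)c2C)N1` differs from compound 3 in one place, with amino in place of benzyloxy on a carbonyl carbon. The same difference, cut one bond further out, reads benzyloxycarbonyl to carbamoyl. Going by the values given here, no measured pair isolates this change, so the expected direction rests on the structural difference alone. A modest rise in this assay is expected, and a reading that stays at the limit remains possible. Among the compounds with values here, the estimate is anchored on compound 2 at 1.6 ug/mL, the one number available. The expected change is an at least 2.1-fold higher number from compound 3 to compound 4 (0.33 log units; beyond the scatter). The estimated value for compound 4 is 3.5 ug/mL, with an expected range of 1.6 ug/mL to 12 ug/mL.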

Compound 4, solubility: 6.3 ug/mL
Compound 4: the middle estimate sits 1.8-fold (0.26 log units) below what was measured; the range from low to high includes it.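

In this assay, for the compounds shown here, amino in place of benzyloxy on a carbonyl carbon gives an at least 3.9-fold higher number from compound 3 to compound 4 (0.59 log units; beyond the scatter), the first step that can be read, and it lies beyond the scatter. Going by these compounds, compound 3 carries only a limit of the assay, < 1.6 ug/mL, and not a number, so the step is a bound and its true size stays unknown. This single change at the carbonyl carbon is enough to take compound 4 off the limit that compound 3 shares with compound 1: the limit of < 1.6 ug/mL in this assay, at which 2 of the 4 values shown sit.

The compounds shown leave open which part of the change carries the step, the departure of benzyloxy with its six-membered aromatic ring or the arrival of amino with its hydrogen-bond donor; a methoxy, a methylamino or a carboxylic acid on the same carbonyl carbon would help to separate the two. They also leave open whether benzyloxycarbonyl to carbamoyl reads the same way with other substituents on the shared core, or whether ethoxycarbonyl to carbamoyl on the cores of compound 1 and compound 2 would give a step of similar size.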